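Swapping 4-Methylpiperazin-1-yl for Piperidin-1-yl on the Propyl Chain

The source may report more compounds than this note shows. Statements on the series, on what has been measured and on what is new or still open speak of the compounds shown alone.

In a functional assay on HeLa cells (Homo sapiens) for antiproliferative activity, read by MTT assay, with a stated time of 48 h (a higher number here means a weaker inhibitor, a lower number a stronger inhibitor), compound 1 `CN1CCN(CCn2c(N)c(-c3nc4ccccc4[nH]3)c3nc(C#N)c(C#N)nc32)CC1` gives > 50000 nM, which is a limit of the assay and not a number. Among the two true numbers, compound 2 `CCN(CC)CCCn1c(N)c(-c2nc3ccccc3[nH]2)c2nc(C#N)c(C#N)nc21` gives 3150 nM and compound 3 `CN1CCN(CCCn2c(N)c(-c3nc4ccccc4[nH]3)c3nc(C#N)c(C#N)nc32)CC1` gives 15600 nM, the higher of the pair. Compound 4 `N#Cc1nc2c(-c3nc4ccccc4[nH]3)c(N)n(CCCN3CCCCC3)c2nc1C#N` keeps the 3-substituted propyl chain of compound 3 but carries piperidin-1-yl in place of 4-methylpiperazin-1-yl, on a saturated chain carbon, three bonds along the chain from an aromatic nitrogen (piperidin-1-yl in place of 4-methylpiperazin-1-yl on a saturated chain carbon, three bonds along the chain from an aromatic nitrogen).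

The closest guide is the change at this same place, where 4-methylpiperazin-1-yl took the place of diethylamino: a 5.0-fold higher number from compound 2 to compound 3 (0.69 log units; beyond the scatter). That step lies beyond the scatter and was modest. Two further steps, an at least 15-fold lower number from compound 1 to compound 2 (1.20 log units; beyond the scatter) and an at least 3.2-fold lower number from compound 1 to compound 3 (0.50 log units; beyond the scatter), also alter the chain and so bear on this change less directly. Moving away from 4-methylpiperazin-1-yl is therefore expected to lower the number in this assay by a modest amount, resting on the single comparison with compound 2 at 3150 nM. The expected change is a 2.8-fold lower number from compound 3 to compound 4 (0.45 log units; beyond the scatter). For compound 4 the estimated value is 5500 nM, with an expected range from 2000 nM to 15000 nM.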

Compound 4, half-maximal inhibitory concentration: 6680 nM
For compound 4 the middle estimate is 1.2-fold (0.08 log units) below the measured one, and the stated range covers the measured number.
By their numbers in this assay, from the lowest: compound 2; then compound 4; then compound 3. At a limit, above all of these: compound 1.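

In this assay, piperidin-1-yl gives the propyl chain a third amine, and it falls between the other two: a 2.3-fold lower number from compound 3 to compound 4 (0.37 log units; beyond the scatter), and a 2.1-fold higher number from compound 2 to compound 4 (0.33 log units; beyond the scatter), both steps modest. The earlier compounds shown here showed only that diethylamino and 4-methylpiperazin-1-yl differ at this place, whereas compound 4 shows that replacing 4-methylpiperazin-1-yl with a ring holding one hetero atom instead of two recovers only part of that difference, leaving the order compound 2, compound 4, compound 3. Compound 1 gives a limit and not a number, so an at least 7.4-fold lower number from compound 1 to compound 4 (0.87 log units; beyond the scatter) is only a bound, and it spans a change of both chain and amine: the limit of > 50000 nM in this assay, at which 1 of the 4 values shown sits.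

The compounds shown leave open whether morpholin-4-yl, pyrrolidin-1-yl or dimethylamino on the propyl chain would fit into this order, and whether piperidin-1-yl on a 2-substituted ethyl chain or on a butyl chain would keep the number of compound 4. With only three amines on the propyl chain, they also do not tell which feature of the amine sets the order.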